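Sulfonyl substituent swap on the piperazine tail: cytotoxicity outlook

The compounds below may be only part of what the source reports. "The series", "measured", "known", "first", "only" and "open" are said of these compounds alone.

The series shares a core carrying a cyanovinyl-substituted aryl ether and an anilino-linked basic tail. Compound 1 `Cc1cc(/C=C/C#N)cc(C)c1Oc1nc(Nc2ccc(CN3CCN(S(C)(=O)=O)CC3)cc2)nc2ccsc12` gives 20700 nM in an ADME assay on MT4 cells (Homo sapiens) for cytotoxicity, read by MTT assay, with a stated time of 5 days; a higher number here means that more compound is tolerated, a lower number that less compound is tolerated. Compound 2 `Cc1cc(/C=C/C#N)cc(C)c1Oc1nc(Nc2ccc(CN3CCNCC3)cc2)nc2sccc12` gives 4030 nM in this assay, and compound 3 `Cc1cc(/C=C/C#N)cc(C)c1Oc1nc(Nc2ccc(N3CCCC(N)C3)cc2)nc2sccc12` gives 4610 nM. Compound 1 therefore stands highest of the three, with compound 3 nearest and compound 2 furthest, both gaps beyond the scatter. Within the data shown here, the one measured single-point step, a 1.1-fold higher number from compound 2 to compound 3 (0.06 log units; within the scatter), concerns the tail ring and not the sulfonyl group.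

Compound 4 `Cc1cc(/C=C/C#N)cc(C)c1Oc1nc(Nc2ccc(CN3CCN(S(N)(=O)=O)CC3)cc2)nc2ccsc12` differs from compound 1 by amino in place of methyl on a sulfonyl sulfur. Among the measured compounds shown here, no measured step touches the sulfonyl sulfur, so nothing among the measured compounds speaks for a shift beyond the scatter in either direction; the only step available, a 1.1-fold higher number from compound 2 to compound 3 (0.06 log units; within the scatter), stayed within it. The expectation is therefore a step of about a 1.0-fold lower number from compound 1 to compound 4 (0.01 log units; within the scatter), that is none beyond the scatter. Compound 4 is estimated at 20000 nM, with a range from 8000 nM to 50000 nM.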

Compound 4, half-maximal cytotoxic concentration: 145000 nM
The estimate for compound 4 lay 7.3-fold (0.86 log units) below the measured number; measured number outside the range, above it.
By their numbers in this assay, from the lowest: compounds 2 and 3 (each within the scatter of the next); then compound 1; then compound 4.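

At the sulfonyl sulfur of the (4-(methylsulfonyl)piperazin-1-yl)methyl tail, the series is sensitive to substitution in this assay, with amino in place of methyl giving a 7.0-fold higher number from compound 1 to compound 4 (0.85 log units; beyond the scatter) on the core of compound 1. Among these compounds, the only earlier step, a 1.1-fold higher number from compound 2 to compound 3 (0.06 log units; within the scatter), concerned the tail ring and gave no reading at this sulfur. The change exchanges one carbon for one nitrogen and adds one hydrogen-bond donor, but no measurement on hand links the step to that donor or otherwise accounts for it.

Open, from the compounds shown here alone, is whether the step is specific to amino or would also appear with dimethylamino, hydroxyl or ethyl on the same sulfur. Also open, going by these compounds, is whether the same exchange would give a comparable step on the core of compound 2.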